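Swapping a nitro group for a methyl group

A few compounds are considered here, and "the series" means these few. Any claim that something is new, unique, unknown or untested is made for them only; others in the source may bear on it.

For the measured compounds named here, in a functional assay on HT-29 cells (Homo sapiens) for inhibition, read by MTT assay (a lower number here means a stronger inhibitor, a higher number a weaker inhibitor), compound 3 `COc1ccc(/C=C2\c3cc(OC)c(OC)c(OC)c3CC[C@@H]2O)cc1[N+](=O)[O-]` gives 1590 nM as the highest number so far. Compound 1 `COc1ccc(/C=C2\c3cc(OC)c(OC)c(OC)c3CC[C@@H]2O)cc1F` gives 3 nM and compound 2 `COc1ccc(/C=C2\c3cc(OC)c(OC)c(OC)c3CC[C@@H]2O)cc1C#N` gives 5 nM on the same core. Compound 4 `COc1ccc(/C=C2\c3cc(OC)c(OC)c(OC)c3CC[C@@H]2O)cc1C` has methyl in place of nitro on an aromatic carbon and is still unmeasured. The steps to nitro were big: a 530-fold higher number from compound 1 to compound 3 (2.72 log units; beyond the scatter) and a 320-fold higher number from compound 2 to compound 3 (2.50 log units; beyond the scatter) are both large, while a 1.7-fold higher number from compound 1 to compound 2 (0.22 log units; within the scatter) stays within the scatter. Going by the values given here, no methyl compound has been measured, so the expectation that methyl will track fluoro and cyano rather than nitro is uncertain. The expected change is a 160-fold lower number from compound 3 to compound 4 (2.20 log units; beyond the scatter) as a large fall in the number. For compound 4 the estimate is 10 nM with an expected range of 2 nM to 200 nM for now.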

Compound 4, half-maximal inhibitory concentration: 2560 nM
Compound 4: the middle estimate sits 260-fold (2.41 log units) below what was measured; the whole stated range lies below it.
By their numbers in this assay, from the lowest: compounds 1 and 2 (each within the scatter of the next); then compounds 3 and 4 (each within the scatter of the next).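

In this assay, a 1.6-fold higher number from compound 3 to compound 4 (0.21 log units; within the scatter) stays within the scatter, so methyl and nitro cannot be told apart at this position. Yet a 510-fold higher number from compound 2 to compound 4 (2.71 log units; beyond the scatter) and an 850-fold higher number from compound 1 to compound 4 (2.93 log units; beyond the scatter) are both large, so on the shared core the four groups fall into two sets: fluoro with cyano, and nitro with methyl. No measurement available here explains what links the members of each set.

Still open, from the compounds shown here alone, is which set a chloro, an amine or a hydroxyl group at this position would join. Going by these compounds, whether the same split holds on other cell lines is also open.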